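Varying the Carbonyl Substituent Ahead of Compound 4

This account rests on a few compounds, and the source may have more. Where it says the series, first, only, none or still open, it means among the compounds named here.

Three compounds have been measured in an assay on a protein complex for inhibition of CDK8/Cyclin C (Homo sapiens), with a stated time of 1 h, tested at 10 uM; on this read-out higher numbers stand for more inhibition at the one concentration tested (going by the name of the read-out) and lower numbers for less inhibition:
compound 1 `CN1CCN(C(=O)/C=C/c2ccncc2-c2ccc3ccccc3c2)CC1` gives 101%;
compound 2 `CNC(=O)/C=C/c1ccncc1-c1ccc2ccccc2c1` gives 101%;
compound 3 `COC(=O)/C=C/c1ccncc1-c1ccc2ccccc2c1` gives 102%.

Compound 3 carries the highest of the three numbers, but neither gap separates it from the others: a number 1 percentage points higher from compound 1 to compound 3 (within the scatter) and a number 1 percentage points higher from compound 2 to compound 3 (within the scatter), with no change at the digits printed from compound 1 to compound 2 (within the scatter) in the same way. All three exchanges sit on the carbonyl carbon, and none of them moves the read-out.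

Compound 4 `CC(C)[C@@H](NC(=O)/C=C/c1ccncc1-c1ccc2ccccc2c1)C(=O)O` changes the same position: (1-carboxy-2-methylpropyl)amino in place of methoxy on a carbonyl carbon. The three measured steps all bear on it, since each swaps the group on that carbonyl carbon, and each stayed within the scatter. For the measured compounds named here, the group entering here is larger and brings a carboxylic acid, which no measured compound shows, so the expectation rests only on the three unchanged steps. On that basis no step beyond the scatter is expected, and the estimated step is a number 7 percentage points lower from compound 3 to compound 4 (within the scatter). Compound 4 is therefore expected to give about 95%, within a range from 75% to 105%.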

Compound 4, a percentage reported as inhibition, at one concentration (the size of the read-out at that concentration, not a potency): 77%
Compound 4: middle estimate off by 18 percentage points, on the high side, and the stated range covers the measured number.
By their numbers in this assay, from the lowest: compound 4; then compounds 1, 2 and 3 (each within the scatter of the next).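

In this assay, for the compounds shown here, the group on the carbonyl carbon no longer appears free to vary, as (1-carboxy-2-methylpropyl)amino in place of methoxy gives a number 25 percentage points lower from compound 3 to compound 4 (beyond the scatter) and so produces the first step beyond the scatter at this position. The same holds on the amide-type nitrogen, where 1-carboxy-2-methylpropyl in place of methyl gives a number 24 percentage points lower from compound 2 to compound 4 (beyond the scatter) and, against 4-methylpiperazin-1-yl on the carbonyl carbon, the exchange gives a number 24 percentage points lower from compound 1 to compound 4 (beyond the scatter) across the same position. No measurement shown here explains this loss of inhibition.

The compounds shown cannot separate the part played by the carboxylic acid from that of the branched chain or the defined stereocentre. A methyl ester in place of the carboxylic acid, or a simple isopropyl group on the amide nitrogen, would bear directly on that question.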